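Stability series: a second fluoro on the pendant phenyl

The source may report more compounds than this note shows. Statements on the series, on what has been measured and on what is new or still open speak of the compounds shown alone.

Compound 1 `Cc1cccc(-c2c([C@H](C)Nc3nc(N)nc(N)c3C#N)cc3ccc(F)cn3c2=O)c1` gives 77% in an ADME assay on microsomes from liver (Rattus norvegicus), read by LC-MS, using NADPH, with a stated time of 30 min, tested at 1 uM; on this read-out higher numbers stand for a more stable compound and lower numbers for a less stable compound. Compound 2 `Cc1cc(F)cc(-c2c([C@H](C)Nc3nc(N)nc(N)c3C#N)cc3ccc(F)cn3c2=O)c1` gives 60% in this assay. The change fluoro in place of hydrogen on an aromatic carbon brings a number 17 percentage points lower from compound 1 to compound 2 (beyond the scatter). Compound 3 `C[C@H](Nc1ncnc(N)c1C#N)c1cc(=O)n2cc(F)ccc2c1-c1cccc(F)c1` gives 79% in this assay; compound 1 and compound 3 sit within the scatter of each other, while compound 2 lies beyond it. The difference between the core of compound 3 and the core of compound 1 is not broken down here. Compound 4 `C[C@H](Nc1ncnc(N)c1C#N)c1cc(=O)n2cc(F)ccc2c1-c1cc(F)cc(F)c1` is not yet measured; it differs from compound 3 by fluoro in place of hydrogen on an aromatic carbon. This is the same kind of change as between compound 1 and compound 2, but the place is not identical: there the entering fluoro is meta to a methyl group, here it is meta to a fluoro group. Because the same kind of change gave a number 17 percentage points lower from compound 1 to compound 2 (beyond the scatter), the expected step is a number 17 percentage points lower from compound 3 to compound 4 (beyond the scatter). Compound 4 is estimated at 62%, expected between 46% and 77%.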

Compound 4, percent of the compound remaining: 60%
Estimate against measurement, compound 4: 2 percentage points above; measured number inside the range.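

The change brings a number 19 percentage points lower from compound 3 to compound 4 (beyond the scatter) in this assay. Across the two cores, which also differ in the group already on the phenyl ring, the loss of stability carries over at a similar size: the same change on two cores in this assay, a number 17 percentage points lower (beyond the scatter) from compound 1 to compound 2 and a number 19 percentage points lower (beyond the scatter) from compound 3 to compound 4, 2 percentage points apart, within the scatter of two such steps. These two pairs do not show why the number falls, nor that the same step would appear on any other core in the series.

Still open, going by these compounds, is whether the loss belongs to fluoro itself or would also follow a chloro or methoxy group at the same place. The compounds shown also leave open how a group such as an amine or a carboxylic acid on the phenyl ring would read on this scale.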